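A few compounds are considered here, and "the series" means these few. Any claim that something is new, unique, unknown or untested is made for them only; others in the source may bear on it.

Three compounds share one core and differ only in the group attached to its carbonyl carbon. Compound 1 `COc1ccc(C(=O)c2ccc3c(c2)C(n2ccccc2=O)=CC(C)(C)O3)cc1` carries a 4-methoxyphenyl there, and in a functional assay (trachea) with Rattus norvegicus as the target (a lower number here means a less potent compound, a higher number a more potent compound, by a factor of ten per unit of this negative logarithm), compound 1 gives 5.72. Compound 2 `CC1(C)C=C(n2ccccc2=O)c2cc(C(=O)c3ccco3)ccc2O1` carries a furan-2-yl, and in this assay compound 2 gives 5.92. Compound 3 `Cc1ccccc1C(=O)c1ccc2c(c1)C(n1ccccc1=O)=CC(C)(C)O2` carries a 2-methylphenyl, and in this assay compound 3 gives 6.25, the highest of the three numbers. The steps between them were a number 0.20 log units higher from compound 1 to compound 2 (within the scatter), a number 0.53 log units higher from compound 1 to compound 3 (beyond the scatter) and a number 0.33 log units higher from compound 2 to compound 3 (beyond the scatter).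

Compound 4 `CC1(C)C=C(n2ccccc2=O)c2cc(-c3ccncc3)ccc2O1` has not yet been measured. It differs from compound 3 as follows: pyridin-4-yl in place of (2-methylphenyl)carbonyl on an aromatic carbon. Going by the values given here, none of the measured steps bears directly on this change: each of them swaps one group for another on the carbonyl carbon, whereas here the whole (2-methylphenyl)carbonyl leaves and a pyridin-4-yl enters in its place. Among the compounds with values here, the measured steps show only that changing the group on the carbonyl carbon shifts the number by a modest amount at most. A move downward is expected, a number 0.65 log units lower from compound 3 to compound 4 (beyond the scatter), because compound 3 already stands at 6.25 and the change removes the part that all measured variations kept. Compound 4 is therefore estimated at 5.6, with a range from 4.9 to 6.3.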

Compound 4, logarithm of the reciprocal of the active concentration, log(1/C): 6.32
Estimate against measurement, compound 4: 0.72 log units below; measured number outside the range, above it.
By their numbers in this assay, from the lowest: compounds 1 and 2 (each within the scatter of the next); then compounds 3 and 4 (each within the scatter of the next).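

Going by these compounds alone, all the earlier compounds kept a carbonyl on this aromatic carbon, and compound 4 shows that in this assay a group without one can stand level with the best of them: the step is a number 0.07 log units higher from compound 3 to compound 4 (within the scatter), although a pyridin-4-yl of 6 heavy atoms has replaced a (2-methylphenyl)carbonyl of 9. Set against the furan-2-yl ketone, the same kind of replacement gives a number 0.40 log units higher from compound 2 to compound 4 (beyond the scatter), so among these compounds the carbonyl link is not required for a number at the upper end of this set, and the position accepts a ring attached directly to the aromatic carbon. Nothing shown here gives a reason for these numbers.

Within the data shown here, with only one directly attached ring in view, the contribution of the ring nitrogen cannot be separated from the loss of the carbonyl, and a plain phenyl on the same carbon would be needed to tell the two apart. Also open, on these data alone, is how a pyridin-3-yl, or a smaller group such as an amine or a carboxylic acid, would fare at this position in this assay.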